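Methyl Carbamate Variant of a Weak Bicyclic Amine Ligand

A few compounds are considered here, and "the series" means these few. Any claim that something is new, unique, unknown or untested is made for them only; others in the source may bear on it.

Measured so far:
Compound 1 `C[C@H]1C[C@@H]1C(=O)N1CC2CNCC2C1`: 13000 nM
Compound 2 `CC(=O)N1CC2CNCC2C1`: 14000 nM

In an assay on CHO cells for displacement of a labelled ligand from Neuronal acetylcholine receptor; alpha3/beta4 (Homo sapiens), read by scintillation counting, with a stated time of 2 h (on this read-out higher numbers stand for weaker inhibition and lower numbers for stronger inhibition), compound 2 gives 14000 nM, and compound 1 gives 13000 nM. Within the data shown here, the one measured step, a 1.1-fold higher number from compound 1 to compound 2 (0.03 log units; within the scatter), shows that exchanging the group on the carbonyl carbon left the number essentially unchanged. Compound 3 `COC(=O)N1CC2CNCC2C1` differs from compound 2 by methoxy in place of methyl on a carbonyl carbon. Among the measured compounds shown here, no measured step tests a methoxy at this place, so the only guidance is the step from compound 1 to compound 2, which altered the same carbonyl substituent and stayed within the scatter. On that basis no shift beyond the scatter is expected in this assay, in either direction, and both measured compounds remain weak binders. Compound 3 is therefore expected to give 15000 nM, with a range from 5000 nM to 45000 nM. The expected step is a 1.1-fold higher number from compound 2 to compound 3 (0.03 log units; within the scatter).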

Compound 3, inhibition constant: 14000 nM
Compound 3: the middle estimate sits 1.1-fold (0.03 log units) above what was measured, within the range that was stated.
By their numbers in this assay, from the lowest: compounds 1, 2 and 3 (each within the scatter of the next).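

In this assay, among these compounds, methoxy is the first group on this carbonyl carbon to bring an oxygen and a hydrogen-bond acceptor, and it gives no change at the digits printed from compound 2 to compound 3 (within the scatter) with no separation from methyl. The wider comparison, a 1.1-fold higher number from compound 1 to compound 3 (0.03 log units; within the scatter) also stays within the scatter, so methyl, methoxy and 2-methylcyclopropyl cannot be told apart at this place, and the change from acetyl to methoxycarbonyl leaves the compound a weak binder. No supporting measurement is available to explain this flat result.

The compounds shown leave open whether a phenyl group on this carbonyl carbon, or a chain carrying an amine or a carboxylic acid, would read any differently. They also leave open whether the shared core would behave differently without a carbonyl group at this place.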